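Solubility in a Shared Core: Three Measured Analogues, One Untested

The compounds below may be only part of what the source reports. "The series", "measured", "known", "first", "only" and "open" are said of these compounds alone.

compound 1 `COc1ccc(F)cc1CNCCCNc1ccnc2cc(C3CCCCC3)ccc12`: 4200 nM
compound 2 `c1coc(CNCCCNc2ccnc3cc(C4CCCCC4)ccc23)c1`: 4200 nM
compound 3 `COc1cccc(CNCCCNc2ccnc3cc(Cc4cc(C)cc(C)c4)ccc23)c1O`: 4200 nM

In a physicochemical assay for solubility, with a stated time of 18 h, at pH 7.4 (a lower number here means a less soluble compound, a higher number a more soluble compound), compound 1 gives 4200 nM, compound 2 gives 4200 nM and compound 3 gives 4200 nM; compound 1 stands level with both of them, its nearest being compound 2 and its furthest compound 3, each within the scatter. Among the measured compounds shown here, the only measured step, no change at the digits printed from compound 1 to compound 2 (within the scatter), changes the group on the saturated chain carbon bound to an amine nitrogen and leaves the reading where it was.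

Compound 4 `COc1ccc(F)cc1CNCCCNc1ccnc2cc(Oc3ccc(Cl)cc3)ccc12` differs from compound 1 at a different place: 4-chlorophenoxy in place of cyclohexyl on an aromatic carbon. For the measured compounds named here, no measured step touches that aromatic carbon, so the step of no change at the digits printed from compound 1 to compound 4 (within the scatter) is expected to stay within the scatter. Compound 4 is therefore estimated at 4200 nM, in the range 1500 nM to 12000 nM.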

Compound 4, solubility: 14500 nM
For compound 4 the middle estimate is 3.5-fold (0.54 log units) below the measured one; measured number outside the range, above it.
By their numbers in this assay, from the lowest: compounds 1, 2 and 3 (each within the scatter of the next); then compound 4.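

In this assay, the aromatic carbon proves to be a place where the reading can move: 4-chlorophenoxy in place of cyclohexyl brings a 3.5-fold higher number from compound 1 to compound 4 (0.54 log units; beyond the scatter). The one earlier step, at the saturated chain carbon, had shown no such movement. Nothing shown gives a reason for this rise.

As far as these compounds go, whether the rise belongs to the ether oxygen, the chlorine or the aromatic ring stays open, as does how a morpholine or a carboxylic acid on that aromatic carbon would read. From the compounds shown here alone, it is also open whether 4-chlorophenoxy would have the same effect with furan-2-yl on the chain.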